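The compounds below may be only part of what the source reports. "The series", "measured", "known", "first", "only" and "open" are said of these compounds alone.

Compound 1 `Oc1cc(C(F)(F)F)ccc1-c1nc(-c2ccccc2O)n(-c2ccc(I)cc2)n1`, which in a functional assay on PC-12 cells (Rattus norvegicus) for cytotoxicity, read by MTT assay, with stated times of 2 h and 24 h, tested at 10 uM (on this read-out higher numbers stand for a stronger effect at the one concentration tested and lower numbers for a weaker effect), gives 105%; compound 2 `N#Cc1ccc(-n2nc(-c3ccc(C(F)(F)F)cc3O)nc2-c2ccccc2O)cc1`, which in this assay gives 98.9%.

For the measured compounds named here, compound 2 stands lowest of the two numbers so far, and its nearest neighbour is compound 1: the step of a number 6.1 percentage points lower from compound 1 to compound 2 (within the scatter) lies within the scatter, so the two compounds cannot be told apart on this read-out. Compound 3 `COc1ccccc1-n1nc(-c2ccc(C(F)(F)F)cc2O)nc1-c1ccccc1O` differs from compound 2 by 2-methoxyphenyl in place of 4-cyanophenyl on an aromatic nitrogen. Going by the values given here, the only measured step, a number 6.1 percentage points lower from compound 1 to compound 2 (within the scatter), changed the same aryl group on the aromatic nitrogen at a different point and left the read-out essentially unchanged, which is the sole guide available here. Nothing measured speaks to a methoxy group or to moving a substituent on that ring, so the bearing of that step is loose. On this footing the step of a number 0.9 percentage points lower from compound 2 to compound 3 (within the scatter) is expected to stay within the scatter, with no clear direction. Compound 3 is therefore estimated to give 98% in this assay, within a range from 80% to 112%.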

Compound 3, a percentage reported as activity, at one concentration (the size of the read-out at that concentration, not a potency): 96.2%
Estimate against measurement, compound 3: 1.8 percentage points above, and the stated range covers the measured number.
By their numbers in this assay, from the lowest: compounds 3, 2 and 1 (each within the scatter of the next).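

With this result the change on the aromatic nitrogen is no longer confined to a 4-substituted phenyl ring. Replacing 4-cyanophenyl with 2-methoxyphenyl gives a step of a number 2.7 percentage points lower from compound 2 to compound 3 (within the scatter), and replacing 4-iodophenyl with 2-methoxyphenyl gives a step of a number 8.8 percentage points lower from compound 1 to compound 3 (within the scatter), so all three compounds lie within the scatter of one another in this assay. Across these three aryl groups, which differ in the name and place of their substituent, this position therefore shows no measurable difference on this read-out, though that holds only for these groups at the one concentration tested. No measurement here offers an explanation for this sameness.

The compounds shown leave open whether this position would tolerate something other than a substituted phenyl ring, such as a longer alkyl chain on the aromatic nitrogen, or a phenyl ring carrying an amine or a carboxylic acid. They also leave open whether 3-methoxyphenyl or 4-methoxyphenyl would read the same as 2-methoxyphenyl, and whether changes to the two hydroxyphenyl groups of the shared core would separate compounds that this position does not.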